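The source may report more compounds than this note shows. Statements on the series, on what has been measured and on what is new or still open speak of the compounds shown alone.

Measured so far:
- Compound 1 `Cc1oc2c([C@H]3CCN(C)C[C@H]3O)c(O)cc(O)c2c(=O)c1C(O)c1cccc(Cl)c1`: 5%
- Compound 2 `Cc1oc2c([C@H]3CCN(C)C[C@H]3O)c(O)cc(O)c2c(=O)c1C(O)c1ccccc1Br`: 21%
- Compound 3 `Cc1oc2c([C@H]3CCN(C)C[C@H]3O)c(O)cc(O)c2c(=O)c1C(O)c1ccc(F)c(Br)c1`: 14%

In a functional assay on MCF7 cells (Homo sapiens) for inhibition, read by MTT assay, with a stated time of 48 h, tested at 10 uM (a higher number here means more inhibition of growth at the concentration tested, a lower number less inhibition of growth), compound 3 gives 14%, within the scatter of both other compounds: a number 9 percentage points higher from compound 1 to compound 3 (within the scatter) and a number 7 percentage points lower from compound 2 to compound 3 (within the scatter). Compound 4 `COc1ccc(C(O)c2c(C)oc3c([C@H]4CCN(C)C[C@H]4O)c(O)cc(O)c3c2=O)cc1Br` differs from compound 3 by methoxy in place of fluoro on an aromatic carbon. Within the data shown here, no measured step isolates this exchange. The nearest evidence comes from changes to the same aromatic ring, and the largest of these, a number 16 percentage points higher from compound 1 to compound 2 (beyond the scatter), is modest. No step beyond the scatter is therefore expected, and the expected change is a number 1 percentage points lower from compound 3 to compound 4 (within the scatter). For compound 4 the estimated value is 13%, with an expected range from 3% to 27%.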

Compound 4, percent growth inhibition at one concentration: 41%
Beside the measured number, compound 4's estimate is 28 percentage points below it, outside the stated range (above it).
By their numbers in this assay, from the lowest: compounds 1, 3 and 2 (each within the scatter of the next, the first and the last beyond it); then compound 4.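

In this assay, among these compounds, the position para to a large group and ortho to a bromo group proves sensitive, since methoxy in place of fluoro brings a number 27 percentage points higher from compound 3 to compound 4 (beyond the scatter) at a site the earlier compounds did not probe. Among the compounds shown here, compound 4 also separates from the other two, with a number 20 percentage points higher from compound 2 to compound 4 (beyond the scatter) and with a number 36 percentage points higher from compound 1 to compound 4 (beyond the scatter) as the only large step, so it is the most active of the four at this concentration. Still open, going by these compounds, is whether ethoxy or an amino group at this position would act as methoxy does, and whether methoxy keeps this effect without the bromo group. No measurement shown here accounts for the rise.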